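Swapping hydroxy for cyano on compound 3

This account rests on a few compounds, and the source may have more. Where it says the series, first, only, none or still open, it means among the compounds named here.

Measured so far in a functional assay on LOX IMVI cells (Homo sapiens) for cytotoxicity (on this read-out higher numbers stand for weaker inhibition of growth and lower numbers for stronger inhibition of growth), for three compounds:
compound 1 `OCCCCC#Cc1ccccc1C#Cc1ccccn1` gives 27700 nM
compound 2 `OCCCCC#Cc1ccccc1C#Cc1cccs1` gives 13900 nM
compound 3 `OCCCCC#Cc1ccccc1C#Cc1ccc(O)cc1` gives 13600 nM

Each value is the concentration needed to halve cell growth, so a lower number means a stronger effect. Compound 3 shares the low end of this small set with one neighbour, as the data show a 1.0-fold lower number from compound 2 to compound 3 (0.01 log units; within the scatter) and also a 2.0-fold lower number from compound 1 to compound 3 (0.31 log units; beyond the scatter) in this set.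

The next molecule, compound 4 `N#Cc1ccc(C#Cc2ccccc2C#CCCCCO)cc1`, keeps the shared core and the hydroxy-ended chain of compound 3 but carries cyano in place of hydroxy on an aromatic carbon, para to a large group cyano in place of hydroxy on an aromatic carbon in the counted terms.

Among the measured compounds shown here, no measured step makes this exact swap, so the evidence is indirect. The three steps available all replace the whole group on a triple-bonded carbon, and they stay small. Even the largest of them is a 2.0-fold lower number from compound 1 to compound 3 (0.31 log units; beyond the scatter) while the other two are a 2.0-fold lower number from compound 1 to compound 2 (0.30 log units; within the scatter) and a 1.0-fold lower number from compound 2 to compound 3 (0.01 log units; within the scatter) in size. A change of one substituent therefore gives little reason to expect a large shift.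

The expected outcome is a 1.1-fold higher number from compound 3 to compound 4 (0.04 log units; within the scatter) in this assay and so no real change in either direction.

The estimate for compound 4 is 15000 nM with an expected range from 6500 nM to 33000 nM in this measurement.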

Compound 4, concentration for 50% growth inhibition: 18300 nM
Estimate against measurement, compound 4: 1.2-fold (0.09 log units) below; the range from low to high includes it.
By their numbers in this assay, from the lowest: compounds 3, 2, 4 and 1 (each within the scatter of the next, the first and the last beyond it).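

In this assay, putting cyano in place of hydroxy on the aromatic carbon, para to a large group, gives a 1.3-fold higher number from compound 3 to compound 4 (0.13 log units; within the scatter). Among the compounds shown here, this is the first step in the set that changes only a substituent on the six-membered aromatic ring, whereas the earlier steps replaced the whole group on the triple-bonded carbon. The hydroxy that leaves counts as a hydrogen-bond donor and the cyano that enters does not, yet the two compounds stay within the scatter of each other, so growth inhibition at this level does not depend on that donor at this position, and no accompanying measurement bears on why the read-out holds.

From the compounds shown here alone, the two groups compared at this position say little about how wide that tolerance is, and it remains open whether an amine, a carboxylic acid or a methoxy group there would leave the number in the same range or move it clearly beyond the scatter. All four compounds also share the same hydroxy-ended chain, so the effect of a longer chain, or of an amine at its end, remains an open question.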